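Moving a Hydroxyl Group on Two Related Cores

The source may report more compounds than this note shows. Statements on the series, on what has been measured and on what is new or still open speak of the compounds shown alone.

Measured compounds:
compound 1, `Oc1cccc(-c2cc(-c3ccco3)cc(-c3cccc(O)c3)n2)c1`, 97.8%
compound 2, `Oc1ccc(-c2cc(-c3ccco3)cc(-c3cccc(O)c3)n2)cc1`, 100%
compound 3, `Oc1cccc(-c2cc(-c3ccoc3)cc(-c3ccccc3O)n2)c1`, 29.5%

Of the compounds shown here, three have been tested in an assay on isolated protein for inhibition of DNA topoisomerase 1 (Homo sapiens), with a stated time of 30 min, tested at 100 uM; a lower number here means a weaker effect, a higher number a stronger effect of the compound at the concentration tested. Compound 1 gives 97.8%. Compound 2 gives 100%. Compound 3 gives 29.5%, the lowest of the three, and its distance from compound 1 and from compound 2 lies beyond the scatter in both cases.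

Compound 1 and compound 2 differ in one place, (4-hydroxyphenyl in place of 3-hydroxyphenyl on an aromatic carbon), and the step of a number 2.2 percentage points higher from compound 1 to compound 2 (within the scatter) lies within the scatter, so the two cannot be ordered. Compound 3 stands on a different core from compound 1; the difference between the two cores is not broken down here.

Compound 4, `Oc1ccc(-c2cc(-c3ccoc3)cc(-c3ccccc3O)n2)cc1`, has not yet been measured. It differs from compound 3 by 4-hydroxyphenyl in place of 3-hydroxyphenyl on an aromatic carbon. Within the data shown here, this is the same kind of change as the one from compound 1 to compound 2, but not the same: in compound 3 the place is meta to a 2-hydroxyphenyl group and meta to a furan-3-yl group, whereas in compound 1 it is meta to a 3-hydroxyphenyl group and meta to a furan-2-yl group. Among the measured compounds shown here, the only measured precedent for this change is the small step in this assay from compound 1 to compound 2, so compound 4 is expected to sit close to compound 3, with a step of about a number 3.5 percentage points higher from compound 3 to compound 4 (within the scatter), though the different surroundings leave room for a larger move. Compound 4 is therefore estimated at 33%, within a range from 15% to 55%.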

Compound 4, a percentage reported as inhibition, at one concentration (the size of the read-out at that concentration, not a potency): 30.1%
Estimate against measurement, compound 4: 2.9 percentage points above; measured number inside the range.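

In this assay, 4-hydroxyphenyl in place of 3-hydroxyphenyl on an aromatic carbon next to the ring nitrogen gives a number 0.6 percentage points higher from compound 3 to compound 4 (within the scatter), so this pair cannot be ordered any more than the first pair could. The change therefore carries over from one core to the other with no step that can be told from the scatter, and the two cores do not differ in how they take it: the same change on two cores in this assay, a number 2.2 percentage points higher (within the scatter) from compound 1 to compound 2 and a number 0.6 percentage points higher (within the scatter) from compound 3 to compound 4, 1.6 percentage points apart, within the scatter of two such steps

Among these compounds, this does not show that the change is without effect in general: only two cores are at hand, each read-out comes from one concentration and is not a potency, and compound 2 stands at 100%, so on that core a further rise could hardly register.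

All the compounds shown carry a hydroxyl on the phenyl ring at this place, which leaves open how an amine, a methoxy group or a carboxylic acid there would read. Also open, from the compounds shown here alone, is what the furan-3-yl group and the 2-hydroxyphenyl group each contribute on their own, as the two cores are not separated here into single changes.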